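This account rests on a few compounds, and the source may have more. Where it says the series, first, only, none or still open, it means among the compounds named here.

Measured compounds:
- compound 1, `Cc1ccc(-c2ccnc(C(=O)Nc3ccc(Oc4ccnc5[nH]ccc45)c(F)c3)c2)c(C)c1`: 6220 nM
- compound 2, `CCc1ccc(-c2ccnc(C(=O)Nc3ccc(Oc4ccnc5[nH]ccc45)c(F)c3)c2)cc1`: 7470 nM

In a functional assay on MCF7 cells (Homo sapiens) for cytotoxicity, read by MTT assay, with a stated time of 72 h (a higher number here means a weaker inhibitor, a lower number a stronger inhibitor), compound 2 gives the highest of the two numbers, and its nearest neighbour is compound 1, to which it stands within the scatter, as the step of a 1.2-fold higher number from compound 1 to compound 2 (0.08 log units; within the scatter) shows. Compound 3, `O=C(Nc1ccc(Oc2ccnc3[nH]ccc23)c(F)c1)c1cc(-c2ccc(F)cc2)ccn1`, has not yet been measured. It differs from compound 2 in one place: fluoro in place of ethyl on an aromatic carbon. Among the compounds with values here, only one measured step exists, the one from compound 1 to compound 2, and it concerns a different exchange on the same ring; it was small and within the scatter. Within the data shown here, no measured step touches the exchange of ethyl for fluoro, so there is no basis for expecting a change beyond the scatter in this assay. Compound 3 is therefore estimated to give 7000 nM, with a range from 3000 nM to 16000 nM, which means an expected step of a 1.1-fold lower number from compound 2 to compound 3 (0.03 log units; within the scatter).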

Compound 3, half-maximal inhibitory concentration: 9520 nM
The estimate for compound 3 lay 1.4-fold (0.13 log units) below the measured number; low and high end bracket the measured number.
By their numbers in this assay, from the lowest: compounds 1, 2 and 3 (each within the scatter of the next).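

In this assay, exchanging ethyl for fluoro on the aromatic carbon para to a large group gives a 1.3-fold higher number from compound 2 to compound 3 (0.11 log units; within the scatter), and the wider exchange of 2,4-dimethylphenyl for 4-fluorophenyl gives a 1.5-fold higher number from compound 1 to compound 3 (0.18 log units; within the scatter). Within the data shown here, the earlier compounds showed only two alkyl-bearing phenyl groups at this place; with fluoro as the substituent, the step from ethyl to a single fluorine atom also stays within the scatter, and all three compounds lie within the scatter of one another. Nothing at hand offers an explanation for this result.

On these data alone, all three compounds carry a substituted phenyl group on the same core, so it remains open whether an amine, a carboxylic acid or a longer chain in place of fluoro would give a step beyond the scatter in this assay. As far as these compounds go, the effect of changes elsewhere on the shared core also remains open.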